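This account rests on a few compounds, and the source may have more. Where it says the series, first, only, none or still open, it means among the compounds named here.

Going by the values given here, compound 1 `Cc1cc(C(=O)O)nn1-c1ccc(S(=O)(=O)NC(=O)NCc2ccccc2)cc1` in a functional assay on the whole organism (blood, strain albino) with Mus musculus as the target, with stated times of 6 days and 4 h, at a dose of 0.4 mmol/kg by the oral route (on this read-out lower numbers stand for less inhibition and higher numbers for more inhibition at the one dose given (going by the name of the read-out)), gives 0%, the lowest of the two numbers measured so far. Compound 2 `CCCNC(=O)NS(=O)(=O)c1ccc(-n2nc(C(=O)O)cc2C)cc1` in this assay gives 1%; the step of a number 1 percentage points higher from compound 1 to compound 2 (within the scatter) is within the scatter, so the two read-outs cannot be told apart. Compound 3 `Cc1cc(C)n(-c2ccc(S(=O)(=O)NC(=O)NCc3ccccc3)cc2)n1` has not yet been measured in this assay. It differs from compound 1 in one place: methyl in place of carboxy on an aromatic carbon. Cut one bond further out, the change reads 3-carboxy-5-methyl-1H-pyrazol-1-yl to 3,5-dimethyl-1H-pyrazol-1-yl. Among the compounds with values here, no measured step touches this part of the shared core; the only step at hand, from compound 1 to compound 2, concerns a saturated chain carbon bound to an amide-type nitrogen and was itself within the scatter. Within the data shown here, both measured compounds sit at the bottom of the read-out, and nothing so far points to a rise beyond the scatter for a change of this kind. The step of a number 2 percentage points higher from compound 1 to compound 3 (within the scatter) is therefore expected to stay within the scatter. Compound 3 is estimated at 2%, with a range from 0% to 12% in this assay.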

Compound 3, a percentage reported as inhibition, in the whole organism at one dose (the size of the read-out at that dose, not a potency): < 1%
Compound 3: a limit, no number; the forecaster's own chance of this, stated with the estimate: 0%; middle value at least 1 percentage points away from the limit.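

In this assay compound 3 gives < 1%, which is a limit and not a number. No step from compound 1 to compound 3 can be read, because the result stops at this limit: the limit of < 1% in this assay, at which 1 of the 3 values shown sits.

The compounds shown leave open whether methyl in place of carboxy on this aromatic carbon alters the read-out at all.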